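From an allyl chain to a hydroxypropyl chain

The source may hold more compounds than are shown below. What is called first, only, known or untested is meant among the compounds shown, and "the series" means these compounds.

Compound 1 `C=CCn1c(=O)c2[nH]cnc2n(CCC)c1=O` gives 1600 nM in a functional assay (trachea) with Cavia porcellus as the target (a lower number here means that less compound is needed, a higher number that more compound is needed for the effect), the lowest of the two numbers measured. Compound 2 `CCCn1c(=O)n(CC(=O)O)c(=O)c2[nH]cnc21` gives 41000 nM in this assay. Compound 3 `CCCn1c(=O)n(CCCO)c(=O)c2[nH]cnc21` differs from compound 1 by 2-hydroxyethyl in place of vinyl on a saturated chain carbon bound to an aromatic nitrogen. Within the data shown here, the one measured step that bears on this change is a 26-fold higher number from compound 1 to compound 2 (1.41 log units; beyond the scatter), a large rise when a carboxy group enters at the same place. Here a 2-hydroxyethyl group enters instead, and a smaller rise is expected, a 2.8-fold higher number from compound 1 to compound 3 (0.45 log units; beyond the scatter). Compound 3 is estimated at 4500 nM, with a range from 1500 nM to 14000 nM.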

Compound 3, half-maximal effective concentration: 5100 nM
Estimate against measurement, compound 3: 1.1-fold (0.05 log units) below; the range from low to high includes it.
By their numbers in this assay, from the lowest: compound 1; then compound 3; then compound 2.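

In this assay, the group entering on the saturated chain carbon bound to an aromatic nitrogen sets how far the number rises: 2-hydroxyethyl in place of vinyl gives a 3.2-fold higher number from compound 1 to compound 3 (0.50 log units; beyond the scatter), while 2-hydroxyethyl in place of carboxy gives an 8.0-fold lower number from compound 2 to compound 3 (0.91 log units; beyond the scatter). Neither replacement of vinyl matches compound 1, so at this place the vinyl group gives the lowest number of the three. Nothing shown here explains these differences. From the compounds shown here alone, it remains open whether an amine or a longer chain at this place would fall below compound 1, and whether a methoxy group would behave like the hydroxyl of compound 3.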